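A few compounds are considered here, and "the series" means these few. Any claim that something is new, unique, unknown or untested is made for them only; others in the source may bear on it.

Compounds 1, 2 and 3 share one core and differ only in the aromatic group attached to the carbon with a double bond to nitrogen. Compound 1 `Cc1ccc(/C=N/N(C(=O)c2ccccc2)C(=O)c2ccncc2)cc1` carries a 4-methylphenyl, compound 2 `COc1cc(/C=N/N(C(=O)c2ccccc2)C(=O)c2ccncc2)ccc1O` a 4-hydroxy-3-methoxyphenyl and compound 3 `CSc1ccc(/C=N/N(C(=O)c2ccccc2)C(=O)c2ccncc2)cc1` a 4-(methylsulfanyl)phenyl. In an ADME assay on HEL cells (Homo sapiens) for cytotoxicity (a lower number here means that less compound is tolerated, a higher number that more compound is tolerated), compound 1 gives > 100 ug/mL, which is a limit of the assay rather than a number. Compound 2 gives > 100 ug/mL in this assay, again a limit. Compound 3 gives > 100 ug/mL in this assay, also a limit. Because all three sit at the limit of > 100 ug/mL in this assay, at which 3 of the 3 values shown sit, the steps a step that the two limits leave unreadable from compound 1 to compound 2, a step that the two limits leave unreadable from compound 1 to compound 3 and a step that the two limits leave unreadable from compound 2 to compound 3 cannot be read in size, and compound 3 stands at the limit, level with the other two as far as can be seen.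

Compound 4 `CSc1ccc(/C=N/NC(=O)c2ccncc2)cc1` differs from compound 3 in one place: hydrogen in place of benzoyl on an amide-type nitrogen. Going by the values given here, none of the measured steps touches the amide-type nitrogen, and none of them gave a readable size, so there is nothing to point toward a step beyond the scatter. The step of a number no higher from compound 3 to compound 4 (the limit leaves the size open) is therefore expected to be none beyond the scatter. For compound 4 in this assay the estimate is 100 ug/mL, most likely reported once more as a limit.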

Compound 4, minimum cytotoxic concentration: > 100 ug/mL
Compound 4 ended at the assay's limit; the forecaster's own chance of this, stated with the estimate: 85%; the middle value lies on the limit itself.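

Compound 3 and compound 4 both end at a limit of the assay, so the size of the step that swaps benzoyl for hydrogen cannot be read: the limit of > 100 ug/mL in this assay, at which 4 of the 4 values shown sit.

The compounds shown leave open what concentration of any of these four first harms the cells in this assay, and whether either change shifts that concentration at all.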